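Stripping the Halogens from a Benzamide Cap

A few compounds are considered here, and "the series" means these few. Any claim that something is new, unique, unknown or untested is made for them only; others in the source may bear on it.

Three amides on a shared core have been tested in a functional assay on U-251 cells (Homo sapiens) for antiproliferative activity, read by MTT assay, with a stated time of 72 h; on this read-out higher numbers stand for weaker inhibition and lower numbers for stronger inhibition. Compound 1 `Cc1nc(C(=O)Nc2ccc(Cl)c(-c3nnc4c(Cl)cccn34)c2)cs1` gives 74300 nM. Compound 2 `CS(=O)(=O)c1ccc(C(=O)Nc2ccc(Cl)c(-c3nnc4c(Cl)cccn34)c2)cc1` stops at the limit of the assay, > 100000 nM. Compound 3 `O=C(Nc1ccc(Cl)c(-c2nnc3c(Cl)cccn23)c1)c1c(F)cccc1Cl` also stops at a limit, > 100000 nM, so its standing is known only as a limit and not as a number. Most of the values shown sit at the limit of > 100000 nM in this assay, at which 2 of the 3 values shown sit. The steps of an at least 1.3-fold higher number from compound 1 to compound 2 (0.12 log units; that floor lies within the scatter) and an at least 1.3-fold higher number from compound 1 to compound 3 (0.12 log units; that floor lies within the scatter) have floors within the scatter, and the step that the two limits leave unreadable from compound 2 to compound 3 cannot be read. Compound 4 `O=C(Nc1ccc(Cl)c(-c2nnc3c(Cl)cccn23)c1)c1ccccc1` carries the change (phenyl in place of 2-chloro-6-fluorophenyl on a carbonyl carbon). Among the measured compounds shown here, no measured step touches this change, so no shift beyond the scatter is expected in either direction. Compound 4 is expected to give 100000 nM, within 30000 nM to 300000 nM, an estimated step of a number no higher from compound 3 to compound 4 (the limit leaves the size open).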

Compound 4, half-maximal inhibitory concentration: 73500 nM
Beside the measured number, compound 4's estimate is 1.4-fold (0.13 log units) above it; measured number inside the range.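

The step of a 1.0-fold lower number from compound 1 to compound 4 (0.00 log units; within the scatter) shows that phenyl and 2-methyl-1,3-thiazol-4-yl on the carbonyl carbon cannot be told apart in this assay at this level of activity. Losing the two halogens or the methylsulfonyl gives the steps of an at least 1.3-fold lower number from compound 3 to compound 4 (0.13 log units; that floor lies within the scatter) and an at least 1.3-fold lower number from compound 2 to compound 4 (0.13 log units; that floor lies within the scatter) and neither is shown to matter. Those two steps are only floors, set by a limit: the limit of > 100000 nM in this assay, at which 2 of the 4 values shown sit.

Still open, from the compounds shown here alone, is whether any group here can bring the number down beyond the scatter. An amine or a carboxylic acid on the phenyl ring might answer that.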